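Working notes: compound 1 to compound 4, halogen exchange on the ketone aryl

The compounds below may be only part of what the source reports. "The series", "measured", "known", "first", "only" and "open" are said of these compounds alone.

Measured so far:
compound 1 `COc1cc(-c2cc(/C=C/C(=O)c3ccc(Cl)c(Cl)c3)[nH]n2)cc(OC)c1OC`: 67%
compound 2 `COc1ccc(-c2cc(/C=C/C(=O)c3ccc(N)cc3)[nH]n2)cc1OC`: 87%
compound 3 `COc1ccc(-c2cc(/C=C/C(=O)c3ccc(N)cc3)[nH]n2)cc1`: 61%

In a functional assay on NCI-H522 cells (Homo sapiens) for cytotoxicity, read by sulforhodamine B assay, with a stated time of 48 h, tested at 1 uM (on this read-out higher numbers stand for a weaker effect at the one concentration tested and lower numbers for a stronger effect), compound 1 gives 67%, the second highest of the three numbers. Its nearest neighbour is compound 3, which gives 61%, a gap that lies within the scatter, so no order between compound 1 and compound 3 can be claimed. Compound 2 gives 87%, beyond the scatter from compound 1.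

Going by the values given here, only one single-point step is available among the measured compounds: a number 26 percentage points lower from compound 2 to compound 3 (beyond the scatter). That step concerns a methoxy group on the aryl attached to the shared core and says nothing about the group on the carbonyl carbon.

The change now followed is 3,4-difluorophenyl in place of 3,4-dichlorophenyl on a carbonyl carbon, giving compound 4 `COc1cc(-c2cc(/C=C/C(=O)c3ccc(F)c(F)c3)[nH]n2)cc(OC)c1OC`. Among the compounds with values here, no measured pair exchanges one halogen for another on the 3,4-dichlorophenyl, so there is no step from which a direction could be read. In the absence of such a step, compound 4 is expected to stay near compound 1, with a number 3 percentage points higher from compound 1 to compound 4 (within the scatter) estimated as not beyond the scatter.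

The estimate for compound 4 is therefore 70%, within a range of 50% to 90%.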

Compound 4, a percentage reported as activity, at one concentration (the size of the read-out at that concentration, not a potency): 71%
Beside the measured number, compound 4's estimate is 1 percentage points below it; low and high end bracket the measured number.
By their numbers in this assay, from the lowest: compounds 3, 1 and 4 (each within the scatter of the next); then compound 2.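

In this assay, going by these compounds alone, the step at this position is a number 4 percentage points higher from compound 1 to compound 4 (within the scatter), the first comparison in which only the group on a carbonyl carbon differs, and it leaves compound 1 and compound 4 without an order. Within the data shown here, the exchange of 3,4-dichlorophenyl for 3,4-difluorophenyl therefore gives no readable effect at this place, whereas the only earlier step, a number 26 percentage points lower from compound 2 to compound 3 (beyond the scatter), concerned a methoxy group on the aryl attached to the shared core and lay beyond the scatter. No available data bear on why this halogen exchange leaves the read-out within the scatter.

From the compounds shown here alone, it remains open whether this insensitivity extends beyond the two halogen-bearing groups, for instance to an unsubstituted phenyl or to a phenyl carrying a nitrile or a carboxylic acid on the same carbonyl carbon. The amine-bearing aryl of compound 2 and compound 3 also cannot be set against these halogenated aryl groups, as those compounds differ from compound 1 and compound 4 in more than one place.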